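Swapping Methoxy for Methylpiperazinyl at One Aromatic Carbon

The source may report more compounds than this note shows. Statements on the series, on what has been measured and on what is new or still open speak of the compounds shown alone.

Measured so far:
compound 1 `COc1ccc2nc(-c3n[nH]cc3/C=C/c3cccnc3)[nH]c2c1` — 2200 nM
compound 2 `COC(=O)c1cncc(/C=C/c2c[nH]nc2-c2nc3ccc(OC)cc3[nH]2)c1` — 3100 nM

In a functional assay on HCT-116 cells (Homo sapiens) for antiproliferative activity (a lower number here means a stronger inhibitor, a higher number a weaker inhibitor), compound 1 gives 2200 nM, and compound 2 gives 3100 nM; the step of a 1.4-fold higher number from compound 1 to compound 2 (0.15 log units; within the scatter) lies within the scatter, so the two compounds stand together. Compound 3 `CN1CCN(c2ccc3nc(-c4n[nH]cc4/C=C/c4cccnc4)[nH]c3c2)CC1` differs from compound 1 in one place: 4-methylpiperazin-1-yl in place of methoxy on an aromatic carbon. Among the compounds with values here, the only measured step, a 1.4-fold higher number from compound 1 to compound 2 (0.15 log units; within the scatter), changes a different place in the molecule and was itself within the scatter, so no measured step bears on this exchange. The expected step is therefore a 1.1-fold lower number from compound 1 to compound 3 (0.04 log units; within the scatter), with no direction favoured beyond the scatter. Compound 3 is expected to give 2000 nM, in the range 600 nM to 7000 nM.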

Compound 3, half-maximal inhibitory concentration: 190 nM
Compound 3: the middle estimate sits 11-fold (1.02 log units) above what was measured; the whole stated range lies above it.
By their numbers in this assay, from the lowest: compound 3; then compounds 1 and 2 (each within the scatter of the next).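

In this assay, this aromatic carbon responds strongly to the exchange of methoxy for 4-methylpiperazin-1-yl, giving a 12-fold lower number from compound 1 to compound 3 (1.06 log units; beyond the scatter) whereas the change elsewhere in the molecule gave only a 1.4-fold higher number from compound 1 to compound 2 (0.15 log units; within the scatter) and stayed within the scatter. The position therefore accepts a much larger group carrying a six-membered non-aromatic ring, and the number falls with it. Nothing available explains this gain.

From the compounds shown here alone, whether the ring or its nitrogen atoms matter stays open. A morpholine or an open-chain dimethylamino group on this carbon would help separate the two.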